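A few compounds are considered here, and "the series" means these few. Any claim that something is new, unique, unknown or untested is made for them only; others in the source may bear on it.

Two esters of the shared core have been measured in an assay on cells (Oocyte) for inhibition of sodium- and chloride-dependent neutral and basic amino acid transporter B(0+) (Homo sapiens), read by LC-MS, with a stated time of 10 min; on this read-out lower numbers stand for stronger inhibition and higher numbers for weaker inhibition. Compound 1 `N[C@@H](CCC(=O)OC[C@H]1O[C@@H](n2cc(F)c(=O)[nH]c2=O)C[C@@H]1OC(=O)CC[C@H](N)C(=O)O)C(=O)O` gives 2650000 nM in this assay, and compound 2 `CC(C)[C@H](N)C(=O)OC[C@H]1O[C@@H](n2cc(F)c(=O)[nH]c2=O)C[C@@H]1O` gives 980000 nM. Compound 2 thus stands at the lowest of the two numbers; its nearest neighbour, compound 1, returns a higher number, and that gap lies beyond the usual scatter. Compound 3 `N[C@@H](CCC(=O)OC[C@H]1O[C@@H](n2cc(F)c(=O)[nH]c2=O)C[C@@H]1O)C(=O)O` has not yet been measured in this assay. Its structure differs from compound 2 in one place: 3-amino-3-carboxypropyl in place of 1-amino-2-methylpropyl on a carbonyl carbon. Among the measured compounds shown here, no measured pair shows exactly this change, so the expectation rests on compound 1 and compound 2 alone. Compound 1, which also bears the 3-amino-3-carboxypropyl group, gave 2650000 nM, so compound 3 is expected to return a higher number than its parent, with a step of a 2.0-fold higher number from compound 2 to compound 3 (0.31 log units; beyond the scatter) that lies close to the scatter. For compound 3 the estimate in this assay is 2000000 nM, with a range from 700000 nM to 6000000 nM.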

Compound 3, half-maximal inhibitory concentration: 1130000 nM
Estimate against measurement, compound 3: 1.8-fold (0.25 log units) above; low and high end bracket the measured number.
By their numbers in this assay, from the lowest: compounds 2 and 3 (each within the scatter of the next); then compound 1.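

In this assay, the two ester groups on the carbonyl carbon are not told apart: 3-amino-3-carboxypropyl in place of 1-amino-2-methylpropyl gives a 1.2-fold higher number from compound 2 to compound 3 (0.06 log units; within the scatter). The step beyond the scatter lies instead at the oxygen on a saturated carbon, where hydrogen in place of (3-amino-3-carboxypropyl)carbonyl gives a 2.3-fold lower number from compound 1 to compound 3 (0.37 log units; beyond the scatter), so the gap between the two earlier compounds is not carried by the group on the carbonyl carbon alone. Nothing available explains either step.

The compounds shown leave open whether an acetyl group or a longer chain on that carbonyl carbon would read any differently from the two groups tested. They also leave open whether a benzoyl group on the oxygen on a saturated carbon would bring a step like the one seen with (3-amino-3-carboxypropyl)carbonyl.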